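From 4-Fluorobenzyl to 2-Bromobenzyl on a Shared Core

The source may report more compounds than this note shows. Statements on the series, on what has been measured and on what is new or still open speak of the compounds shown alone.

Among the measured compounds shown here, in a functional assay on SW 1116 cells (Homo sapiens) for antiproliferative activity, read by MTT assay, with a stated time of 24 h (on this read-out lower numbers stand for stronger inhibition and higher numbers for weaker inhibition), compound 1 (`Fc1ccccc1CSc1nnc(-c2ccc3c(c2)OCCO3)n1-c1ccccc1`) gives 13600 nM and compound 2 (`Fc1ccc(CSc2nnc(-c3ccc4c(c3)OCCO4)n2-c2ccccc2)cc1`) gives 20800 nM, so compound 2 stands within the scatter of the only other measured number. Compound 3 (`Brc1ccccc1CSc1nnc(-c2ccc3c(c2)OCCO3)n1-c1ccccc1`) has not yet been measured. It carries 2-bromophenyl in place of 4-fluorophenyl on a saturated chain carbon bound to a sulfur. For the measured compounds named here, one measured step bears on this change, the exchange of 2-fluorophenyl for 4-fluorophenyl at that same place, a 1.5-fold higher number from compound 1 to compound 2 (0.18 log units; within the scatter). That step stays within the scatter. Going by the values given here, no measured compound shows what 2-bromophenyl does, so the evidence is thin, and no change beyond the scatter is expected in this assay. The expected step is a 1.4-fold lower number from compound 2 to compound 3 (0.14 log units; within the scatter). Compound 3 is estimated at 15000 nM, with an expected range from 6500 nM to 35000 nM.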

Compound 3, half-maximal inhibitory concentration: 7350 nM
For compound 3 the middle estimate is 2.0-fold (0.31 log units) above the measured one, within the range that was stated.
By their numbers in this assay, from the lowest: compounds 3, 1 and 2 (each within the scatter of the next, the first and the last beyond it).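

Among the compounds shown here, compound 3 gives the first step beyond the scatter at this place: in this assay, 2-bromophenyl in place of 4-fluorophenyl gives a 2.8-fold lower number from compound 2 to compound 3 (0.45 log units; beyond the scatter), whereas the earlier exchange of 2-fluorophenyl for 4-fluorophenyl gave only a 1.5-fold higher number from compound 1 to compound 2 (0.18 log units; within the scatter). Bromo in place of fluoro on an aromatic carbon, taken alone, gives a 1.9-fold lower number from compound 1 to compound 3 (0.27 log units; within the scatter), which stays within the scatter, so neither of these two smaller steps matches the larger one on its own. No measured evidence accounts for this difference.

The three compounds do not separate what the kind of halogen and its place on the ring each contribute to the larger step. Also open, as far as these compounds go, is what an amine or a carboxylic acid on this phenyl ring, or a longer chain on the sulfur, would give.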